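Amide side chains at the limit of the assay

The compounds below may be only part of what the source reports. "The series", "measured", "known", "first", "only" and "open" are said of these compounds alone.

- compound 1 `CCn1c(C(=O)NCCC(=O)OC)ccc1C(CC)(CC)c1ccc(OCS(=O)(=O)c2ccccc2)c(C)c1`: > 50000 nM, a limit
- compound 2 `CCn1c(C(=O)N[C@@H](CC(=O)OC)C(=O)OC)ccc1C(CC)(CC)c1ccc(OCS(=O)(=O)c2ccccc2)c(C)c1`: > 50000 nM, a limit

In a functional assay on BXPC-3 cells (Homo sapiens) for antiproliferative activity, read by MTT assay, with a stated time of 24 h (a lower number here means a stronger inhibitor, a higher number a weaker inhibitor), compound 2 gives > 50000 nM, which is a limit. Compound 1 sits there too: the limit of > 50000 nM in this assay, at which 2 of the 2 values shown sit.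

Compound 3 `CCn1c(C(=O)NCCO)ccc1C(CC)(CC)c1ccc(OCS(=O)(=O)c2ccccc2)c(C)c1` differs from compound 2 by 2-hydroxyethyl in place of 1,2-bis(methoxycarbonyl)ethyl on an amide-type nitrogen, with 2-hydroxyethyl in place of 1,2-bis(methoxycarbonyl)ethyl on an amide-type nitrogen.

Within the data shown here, the only measured step, a step that the two limits leave unreadable from compound 1 to compound 2, gives no size to carry over. No direction can be read from it either. The step expected in this assay is a number no higher from compound 2 to compound 3 (the limit leaves the size open), and this expectation is weak.

Compound 3 is estimated at 50000 nM, with an expected range of 15000 nM to 100000 nM.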

Compound 3, half-maximal inhibitory concentration: 19900 nM
Estimate against measurement, compound 3: 2.5-fold (0.40 log units) above, and the stated range covers the measured number.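

In this assay, the side chain on the amide-type nitrogen can shift the read-out: compound 3 gives 19900 nM, a number rather than a limit. 2-Hydroxyethyl in place of 1,2-bis(methoxycarbonyl)ethyl gives an at least 2.5-fold lower number from compound 2 to compound 3 (0.40 log units; beyond the scatter), and hydroxy in place of methoxycarbonyl on the saturated chain carbon gives an at least 2.5-fold lower number from compound 1 to compound 3 (0.40 log units; beyond the scatter). Only compound 3 lies off the limit: the limit of > 50000 nM in this assay, at which 2 of the 3 values shown sit.

Going by these compounds, it remains open whether the hydroxy itself matters or only the absence of methoxycarbonyl. A carboxylic acid, an amine or a longer chain ending in hydroxy on the amide-type nitrogen would help separate these.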